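The compounds below may be only part of what the source reports. "The series", "measured", "known", "first", "only" and "open" are said of these compounds alone.

In an ADME assay for permeability, using PAMPA, at pH 7.4 (on this read-out higher numbers stand for higher permeability and lower numbers for lower permeability), the measured compounds are:
Compound 1 `O=C(Nc1cccc(-c2nc3ccccc3o2)c1)c1cc([N+](=O)[O-])ccc1Cl`: 45 10^-6 cm/s
Compound 2 `Cc1ccc(-c2nc3ccccc3s2)cc1NC(=O)c1cc([N+](=O)[O-])ccc1Cl`: 41 10^-6 cm/s

Compound 2 sits level with compound 1: their two numbers lie within the usual scatter of repeated measurements, so neither can be ranked above the other. Compound 3 `Cc1ccc(-c2nc3ccccc3o2)cc1NC(=O)c1cc([N+](=O)[O-])ccc1Cl` is compound 2 with one swap, 1,3-benzoxazol-2-yl in place of 1,3-benzothiazol-2-yl on an aromatic carbon. For the measured compounds named here, no pair of measured compounds differs in one place only, so no measured step shows what such a swap does in this assay. Compound 1 also carries 1,3-benzoxazol-2-yl and gives 45 10^-6 cm/s, so nothing in the numbers points to a move beyond the scatter. The expected change is a 1.0-fold higher number from compound 2 to compound 3 (0.01 log units; within the scatter), which would be no step beyond the scatter. For compound 3 the estimate is 42 10^-6 cm/s, with an expected range of 21 10^-6 cm/s to 80 10^-6 cm/s.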

Compound 3, apparent permeability: "below limit of detection" (no number reported)
For compound 3 the study gives words and no number; the estimate stays without a comparison.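

For the compounds shown here, compound 3 is reported in this assay as "below limit of detection", in words and without a number, so no step from compound 2 to compound 3 can be read. No available evidence bears on this result. From the compounds shown here alone, what 1,3-benzoxazol-2-yl in place of 1,3-benzothiazol-2-yl does to the number remains open.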